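The compounds below may be only part of what the source reports. "The series", "measured", "known", "first", "only" and "open" are said of these compounds alone.

Measured in an ADME assay on S9 fraction from liver (Rattus norvegicus) for metabolic stability, read by LC-MS, using NADPH, with a stated time of 60 min, tested at 10 uM; on this read-out lower numbers stand for a less stable compound and higher numbers for a more stable compound:
- compound 1 `CC(C)C(O)Cc1cc(-c2ccnc3[nH]nc(C(F)(F)F)c23)cc(C2(C#N)CC2)c1`: 19%
- compound 2 `N#CC1(c2cc(CC(O)C3CC3)cc(-c3ccnc4[nH]nc(C(F)(F)F)c34)c2)CC1`: 0%
- compound 3 `N#CC1(c2cc(CC(O)C(F)(F)F)cc(-c3ccnc4[nH]nc(C(F)(F)F)c34)c2)CC1`: 71%

Compound 3 stands highest of the three. Next is compound 4 `COCC(O)Cc1cc(-c2ccnc3[nH]nc(C(F)(F)F)c23)cc(C2(C#N)CC2)c1`, with methoxymethyl in place of trifluoromethyl on a saturated chain carbon bound to an oxygen on a saturated carbon and a saturated chain carbon. Two large steps bear on it: a number 52 percentage points higher from compound 1 to compound 3 (beyond the scatter) and a number 71 percentage points higher from compound 2 to compound 3 (beyond the scatter). The modest a number 19 percentage points lower from compound 1 to compound 2 (beyond the scatter) separates the two compounds without trifluoromethyl. Among the measured compounds shown here, no compound measured so far has an oxygen in this group. A large fall is expected, estimated as a number 46 percentage points lower from compound 3 to compound 4 (beyond the scatter). For compound 4 the estimated value is 25%, with an expected range of 5% to 50%.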

Compound 4, percent of the compound remaining: 51%
Compound 4: middle estimate off by 26 percentage points, on the low side; the measured number lies above the stated range.
By their numbers in this assay, from the lowest: compound 2; then compound 1; then compound 4; then compound 3.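

Methoxymethyl shows that trifluoromethyl is not the only group in this place that stands clear of isopropyl and cyclopropyl, with a number 32 percentage points higher from compound 1 to compound 4 (beyond the scatter) and a number 51 percentage points higher from compound 2 to compound 4 (beyond the scatter). Trifluoromethyl still keeps the top place among the four, with a number 20 percentage points lower from compound 3 to compound 4 (beyond the scatter). Nothing on hand explains this order.

Open, from the compounds shown here alone, is whether an amine or a carboxylic acid in this place would hold the number up. Also open, going by these compounds, is whether a longer ether chain, such as ethoxymethyl, would track methoxymethyl.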